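A few compounds are considered here, and "the series" means these few. Any claim that something is new, unique, unknown or untested is made for them only; others in the source may bear on it.

Among the compounds with values here, compound 1 `CC(C)C(c1ccc(-c2ccc3cccc(F)c3c2)[nH]c1=O)N1CCCCC1=O` is the only compound here that gives a plain number in an ADME assay on microsomes from liver (Mus musculus) for metabolic stability; on this read-out lower numbers stand for a shorter-lived compound and higher numbers for a longer-lived compound: compound 1 gives 0.0967 h. Compound 2 `CCn1ncc2c(F)cc(-c3ccc(C(CC)(CC)c4nnc(C)[nH]4)c(=O)[nH]3)cc21` reports only a limit, > 3 h, in this assay. Compound 3 `CCn1ncc2c(F)cc(-c3ccc(C(CC)(CC)c4ncn(C)n4)c(=O)[nH]3)cc21` likewise reports only a limit, > 3 h, in this assay. Within the data shown here, both of those values sit at the limit of > 3 h in this assay, at which 2 of the 3 values shown sit, so the one step between compounds that differ in a single place, a step that the two limits leave unreadable from compound 2 to compound 3, cannot be read in size or direction.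

Compound 4 `CC(C)C(c1noc(=O)[nH]1)c1ccc(-c2ccc3cccc(F)c3c2)[nH]c1=O` differs from compound 1 by a group of 6 heavy atoms (2 carbon, 2 nitrogen, 2 oxygen; one five-membered aromatic ring with 3 hetero atoms) in place of a group of 7 heavy atoms (5 carbon, 1 nitrogen, 1 oxygen; one six-membered non-aromatic ring with 1 hetero atom), on a saturated chain carbon bound to an aromatic carbon and a saturated chain carbon. Among the measured compounds shown here, no measured step covers this exchange, and compounds 2 and 3, which also carry a triazolyl group on a saturated chain carbon bound to an aromatic carbon and two saturated chain carbons, differ from compound 1 in further places as well, so they give no direct reading of the change. The expected step is therefore uncertain, with a 2.1-fold higher number from compound 1 to compound 4 (0.32 log units; beyond the scatter) as a cautious estimate. For compound 4 the expected value in this assay is 0.2 h, within a range from 0.07 h to 0.6 h.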

Compound 4, half-life: > 3 h
Compound 4 ended at the assay's limit (the forecaster's own chance of this, stated with the estimate: 5%); at least 15-fold (1.17 log units) between middle value and limit.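

In this assay, putting the five-membered aromatic ring with 3 hetero atoms in place of the 2-oxopiperidin-1-yl group, on the saturated chain carbon, gives an at least 31-fold higher number from compound 1 to compound 4 (1.49 log units; beyond the scatter). This is the only readable step among the compounds shown, and it shows that a change in this one place can move the short-lived compound 1 all the way to the limit of the read-out. Compound 4 gives > 3 h, a limit and not a number, so the full size of the step stays unknown because of where that value sits: the limit of > 3 h in this assay, at which 3 of the 4 values shown sit.

Among the compounds shown, this is the one replacement at this place that can be compared with compound 1, so it remains open whether the effect needs this particular ring. A carboxylic acid or a primary amide on the same carbon would test that, and any value short of the limit would give a step of readable size.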